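Benzoate esters of the phenol: a second methoxy

This account rests on a few compounds, and the source may have more. Where it says the series, first, only, none or still open, it means among the compounds named here.

Measured so far in a functional assay on HL-60 cells (Homo sapiens) for cytotoxicity, read by MTT assay, with a stated time of 24 h; on this read-out higher numbers stand for weaker inhibition and lower numbers for stronger inhibition:
compound 1 `COC(=O)/C(=C\c1ccc(O)cc1)Sc1ccnc2cc(Cl)ccc12` gives 4310 nM
compound 2 `COC(=O)/C(=C\c1ccc(OC(=O)c2ccc(OC)cc2)cc1)Sc1ccnc2cc(Cl)ccc12` gives 9090 nM
compound 3 `COC(=O)/C(=C\c1ccc(OC(=O)c2cccc(OC)c2)cc1)Sc1ccnc2cc(Cl)ccc12` gives 25500 nM

Compound 3 holds the highest number of the three; its gaps to compound 2 and to compound 1 both lie beyond the scatter, so it is the weakest inhibitor of this set in this assay.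

Compound 4 `COC(=O)/C(=C\c1ccc(OC(=O)c2cc(OC)cc(OC)c2)cc1)Sc1ccnc2cc(Cl)ccc12` differs from compound 3 by methoxy in place of hydrogen on an aromatic carbon. Among the compounds with values here, no measured step adds a second methoxy to this ring; the nearest information is a 2.8-fold higher number from compound 2 to compound 3 (0.45 log units; beyond the scatter), which shows that where the single methoxy sits matters by a modest step, while a 2.1-fold higher number from compound 1 to compound 2 (0.32 log units; beyond the scatter) and a 5.9-fold higher number from compound 1 to compound 3 (0.77 log units; beyond the scatter) show that the ester itself raises the number modestly. A second methoxy of the same kind, on the same ring, is expected to move the number little, if at all, and more likely upward than downward. The expected step is a 1.2-fold higher number from compound 3 to compound 4 (0.07 log units; within the scatter), with a wide range. For compound 4 the estimate in this assay is 30000 nM, between 12000 nM and 75000 nM.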

Compound 4, half-maximal inhibitory concentration: 19000 nM
Beside the measured number, compound 4's estimate is 1.6-fold (0.20 log units) above it; the measured number falls inside the stated range.
By their numbers in this assay, from the lowest: compound 1; then compound 2; then compounds 4 and 3 (each within the scatter of the next).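

In this assay, within the data shown here, the second methoxy, which turns 3-methoxyphenyl into 3,5-dimethoxyphenyl, gives the only step that stays within the scatter: a 1.3-fold lower number from compound 3 to compound 4 (0.13 log units; within the scatter). The added group does not close the gap to the other two compounds, which remains beyond the scatter at a 2.1-fold higher number from compound 2 to compound 4 (0.32 log units; beyond the scatter) and a 4.4-fold higher number from compound 1 to compound 4 (0.64 log units; beyond the scatter), so this position on the ester ring accepts a further methoxy with no readable shift in the number. No measurement is available that bears on why this is so.

Going by these compounds, whether an amine or a carboxylic acid in place of this second methoxy would move the number beyond the scatter remains open. So does whether a plain benzoyl group, with no methoxy on its ring, would lie closer to compound 1.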